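Removing the tert-butoxycarbonyl group from compound 3

The compounds below may be only part of what the source reports. "The series", "measured", "known", "first", "only" and "open" are said of these compounds alone.

Measured in a physicochemical assay for solubility; a higher number here means a more soluble compound, a lower number a less soluble compound:
- compound 1 `O=C(c1ccccn1)N1CCC(NS(=O)(=O)c2cc(S(=O)(=O)c3ccccc3)ccc2C(F)(F)F)CC1` gives 100000 nM
- compound 2 `O=C(O)CCCC(=O)N1CCC(NS(=O)(=O)c2cc(S(=O)(=O)c3ccccc3)ccc2C(F)(F)F)CC1` gives 50000 nM
- compound 3 `CC(C)(C)OC(=O)N1CC[C@@H](C(=O)N2CCC(NS(=O)(=O)c3cc(S(=O)(=O)c4ccccc4)ccc3C(F)(F)F)CC2)C1` gives 12500 nM

Compound 3 at 12500 nM has the lowest of the three numbers, and its gaps to both other compounds lie beyond the scatter. Compound 4 `O=C([C@H]1CCNC1)N1CCC(NS(=O)(=O)c2cc(S(=O)(=O)c3ccccc3)ccc2C(F)(F)F)CC1` carries pyrrolidin-3-yl in place of 1-(tert-butoxycarbonyl)pyrrolidin-3-yl on a carbonyl carbon, and the rest of compound 3 is unchanged.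

All three measured steps vary the group on this same carbonyl carbon. Two of them end at compound 3 and are modest: an 8.0-fold lower number from compound 1 to compound 3 (0.90 log units; beyond the scatter) and a 4.0-fold lower number from compound 2 to compound 3 (0.60 log units; beyond the scatter) both lie beyond the scatter. The third, a 2.0-fold lower number from compound 1 to compound 2 (0.30 log units; within the scatter), stays within it. Neither compound 1 nor compound 2 carries the tert-butoxycarbonyl group, and among these three compounds none goes against the lower number for the compound that does. Among the compounds with values here, no measured step removes that group alone, so the evidence is indirect. A modest rise is expected, of about the size of the two steps ending at compound 3, read in reverse. The expected change is a 4.0-fold higher number from compound 3 to compound 4 (0.60 log units; beyond the scatter) (an estimate). In this assay compound 4 is estimated at 50000 nM (range 20000 nM to 100000 nM).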

Compound 4, solubility: 25000 nM
Compound 4: middle estimate off by 2.0-fold (0.30 log units), on the high side; the measured number falls inside the stated range.
By their numbers in this assay, from the lowest: compounds 3, 4, 2 and 1 (each within the scatter of the next, the first and the last beyond it).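

Within the data shown here, removing the tert-butoxycarbonyl group gives the first direct reading of that group at this carbonyl carbon, and in this assay the step (a 2.0-fold higher number from compound 3 to compound 4 (0.30 log units; within the scatter)) leaves compound 3 and compound 4 unseparated. Compound 4 also cannot be separated from the 3-carboxypropyl amide (a 2.0-fold lower number from compound 2 to compound 4 (0.30 log units; within the scatter)), so pyrrolidin-3-yl, 3-carboxypropyl and 1-(tert-butoxycarbonyl)pyrrolidin-3-yl no longer divide cleanly into two sets on this carbonyl carbon, even though compound 2 and compound 3 remain apart. The pyridin-2-yl amide does remain apart from compound 4 (a 4.0-fold lower number from compound 1 to compound 4 (0.60 log units; beyond the scatter)). Compound 4 lacks the tert-butoxycarbonyl group, and it goes against any reading in which that group alone marks the low end of the series.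

Still open, as far as these compounds go, is whether a pyridin-3-yl group, a piperidin-4-yl group or an acetyl on the pyrrolidine nitrogen would fall with compound 1 or with compound 4 in this assay, which would show whether compound 1 stands apart through its pyridin-2-yl group specifically. The data shown offer no measurement that explains any of these steps.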